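The source may hold more compounds than are shown below. What is called first, only, known or untested is meant among the compounds shown, and "the series" means these compounds.

In a functional assay on HCT-15 cells (Homo sapiens) for antiproliferative activity (a lower number here means a stronger inhibitor, a higher number a weaker inhibitor), compound 1 `COc1ccc(S(=O)(=O)Oc2ccccc2NC(=O)c2ccncc2)cc1` gives 89 nM. Compound 2 `COc1ccc(S(=O)(=O)Oc2ccccc2NC(=O)Nc2ccccc2)cc1` stands at a limit of the assay, > 10000 nM. Compound 3 `COc1ccc(S(=O)(=O)Oc2ccccc2NC(=O)c2ccnc3ccccc23)cc1` also stands at a limit, > 10000 nM. Compound 4 `COc1ccc(S(=O)(=O)Oc2ccccc2NC(=O)c2ccco2)cc1` carries furan-2-yl in place of quinolin-4-yl on a carbonyl carbon. Among the compounds with values here, two measured steps bear on this change. Quinolin-4-yl in place of pyridin-4-yl gave an at least 110-fold higher number from compound 1 to compound 3 (2.05 log units; beyond the scatter), and anilino in place of pyridin-4-yl gave an at least 110-fold higher number from compound 1 to compound 2 (2.05 log units; beyond the scatter), both large. Furan-2-yl is a single aromatic ring, like the pyridin-4-yl of compound 1 at 89 nM, so a lower number is expected. Compound 2 also holds a single ring, however, so the range stays wide. The expected step is an at least 10-fold lower number from compound 3 to compound 4 (1.00 log units; beyond the scatter). For compound 4 the estimate is 1000 nM, with an expected range from 80 nM to 10000 nM.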

Compound 4, half-maximal inhibitory concentration: 19 nM
Compound 4: middle estimate off by 53-fold (1.72 log units), on the high side, and the stated range ends above it.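

In this assay, furan-2-yl on the carbonyl carbon gives an at least 520-fold lower number from compound 3 to compound 4 (2.72 log units; beyond the scatter), and likewise an at least 520-fold lower number from compound 2 to compound 4 (2.72 log units; beyond the scatter). It also gives a 4.7-fold lower number from compound 1 to compound 4 (0.67 log units; beyond the scatter), so the ring nitrogen of pyridin-4-yl is not required at this place, and a five-membered aromatic ring is accepted there. The first two steps are only bounds, because compound 2 and compound 3 stand at a limit: the limit of > 10000 nM in this assay, at which 2 of the 4 values shown sit.

On these data alone, whether thiophen-2-yl or a non-aromatic group such as cyclopropyl would hold this activity stays open. So does whether a substituent on the furan ring, such as methyl, would help or harm it.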